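Chloro to hydrogen on compound 3

This account rests on a few compounds, and the source may have more. Where it says the series, first, only, none or still open, it means among the compounds named here.

Read-out in a functional assay on cells (Homo sapiens) for cytotoxicity, read by MTT assay, with a stated time of 24 h (on this read-out higher numbers stand for weaker inhibition and lower numbers for stronger inhibition), for the measured compounds:
compound 1 `CCCCCCCCCCCCCCNC(=O)[C@H](CO)/N=C/c1cccc(OC)c1` gives 31300 nM
compound 2 `CCCCCCCCCCCCCCNC(=O)[C@H](CO)/N=C/c1ccccc1O` gives 19000 nM
compound 3 `CCCCCCCCCCCCCCNC(=O)[C@H](CO)/N=C/c1ccc(Cl)cc1` gives 27500 nM

Compound 3 stands within the scatter of both other measured compounds (a 1.1-fold lower number from compound 1 to compound 3 (0.06 log units; within the scatter)) and (a 1.4-fold higher number from compound 2 to compound 3 (0.16 log units; within the scatter)). Compound 4 `CCCCCCCCCCCCCCNC(=O)[C@H](CO)/N=C/c1ccccc1` carries hydrogen in place of chloro on an aromatic carbon, para to a large group (hydrogen in place of chloro on an aromatic carbon), so 4-chlorophenyl becomes phenyl. Among the measured compounds shown here, no measured step makes this exact exchange. The closest evidence is the two steps above and a third exchange of the aromatic group (a 1.6-fold lower number from compound 1 to compound 2 (0.22 log units; within the scatter)), all within the scatter. No step beyond the scatter is therefore expected in this assay here. The estimated step is a 1.1-fold lower number from compound 3 to compound 4 (0.02 log units; within the scatter) and it is expected to stay within the scatter. Compound 4 is expected at 26000 nM (estimated range 14000 nM to 48000 nM).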

Compound 4, half-maximal inhibitory concentration: 7670 nM
The estimate for compound 4 lay 3.4-fold (0.53 log units) above the measured number, outside the stated range (below it).
By their numbers in this assay, from the lowest: compound 4; then compounds 2, 3 and 1 (each within the scatter of the next).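

In this assay, the phenyl of compound 4 gives a lower number than each substituted ring (a 3.6-fold lower number from compound 3 to compound 4 (0.55 log units; beyond the scatter)) (a 2.5-fold lower number from compound 2 to compound 4 (0.39 log units; beyond the scatter)) (a 4.1-fold lower number from compound 1 to compound 4 (0.61 log units; beyond the scatter)), all beyond the scatter, whereas exchanges among the substituted rings stayed within it. The listed chloro, hydroxy and methoxy rings therefore all sit apart from the unsubstituted ring, with no compound shown going against this. No measurement here bears on why the number falls.

From the compounds shown here alone, whether a fluoro or an amine on this ring would also stay with the substituted compounds remains open. So does whether the step from chloro to hydrogen holds with a shorter chain.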